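Iodo in Place of Propyl on the Aromatic Ring

The source may hold more compounds than are shown below. What is called first, only, known or untested is meant among the compounds shown, and "the series" means these compounds.

Compound 2 `CCCc1cc(C)c(Oc2nc(C)cc(OC(CC)CC)c2C)c(C)c1` was tested in a functional assay on the whole organism for displacement of a labelled ligand, with Rattus norvegicus as the target, at a dose of 3.2 mg/kg by the subcutaneous route (a higher number here means more inhibition at the dose given (going by the name of the read-out), a lower number less inhibition), where compound 2 gives 34%. Among the measured compounds shown here, of the two compounds measured so far it stands lowest; its nearest neighbour, compound 1 `CCc1cc(C)c(Oc2nc(C)cc(OC(CC)CC)c2C)c(C)c1`, gives 56%. For the measured compounds named here, the one measured step runs a number 22 percentage points lower from compound 1 to compound 2 (beyond the scatter), a modest fall beyond the scatter for methyl in place of hydrogen on a saturated chain carbon, two bonds along the chain from an aromatic carbon.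

Compound 3 `CCC(CC)Oc1cc(C)nc(Oc2c(C)cc(I)cc2C)c1C` has not yet been measured. It differs from compound 2 by iodo in place of propyl on an aromatic carbon, on an aromatic carbon of a six-membered aromatic ring of carbon only. Going by the values given here, no measured step covers such an exchange; the only step recorded concerns lengthening the chain on that ring, not replacing it with a halogen. Since compound 1 with its shorter chain gives 56% and the change here removes the chain entirely, compound 3 is expected to rise somewhat, with wide uncertainty. The expected step is a number 11 percentage points higher from compound 2 to compound 3 (beyond the scatter). The estimate for compound 3 is 45%, between 15% and 75%.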

Compound 3, a percentage reported as inhibition, in the whole organism at one dose (the size of the read-out at that dose, not a potency): 72%
Beside the measured number, compound 3's estimate is 27 percentage points below it; the measured number falls inside the stated range.
By their numbers in this assay, from the lowest: compound 2; then compound 1; then compound 3.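

The earlier compounds shown here showed only that, in this assay, a longer alkyl chain at this position on the aromatic ring goes with a lower number. Compound 3 shows that the position is not confined to alkyl chains: the reading runs a number 38 percentage points higher from compound 2 to compound 3 (beyond the scatter) and a number 16 percentage points higher from compound 1 to compound 3 (beyond the scatter), so iodo, a single iodine atom, gives a higher number than either the propyl or the ethyl chain. No measurement at hand bears on why this exchange raises the number.

The compounds shown leave open whether the gain belongs to iodine itself or simply comes with losing the chain. As far as these compounds go, how a bromo group, a plain hydrogen or an amine would read at this same position also remains open.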